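This account rests on a few compounds, and the source may have more. Where it says the series, first, only, none or still open, it means among the compounds named here.

Compound 3 `Cc1nnc(COc2cnn(C(C)(C)C)c(=O)c2Cl)o1` stands at the edge of what this set can show: in a functional assay on the whole organism for inhibition, with Mythimna separata as the target, with a stated time of 5 days (a lower number here means that less compound is needed, a higher number that more compound is needed for the effect), compound 3 gives > 300 ug/mL, which is a limit of the assay and not a number. Within the data shown here, the one measured neighbour, compound 1 `Cc1ccc(-c2nnc(COc3cnn(C(C)(C)C)c(=O)c3Cl)o2)cc1`, gives 19.9 ug/mL in this assay. Among the measured compounds shown here, the step of an at least 15-fold higher number from compound 1 to compound 3 (1.17 log units; beyond the scatter) is therefore large, and it is the only measured step that bears on the change now considered. Compound 2 `CCn1ncc(OCc2nnc(-c3ccccc3)o2)c(Cl)c1=O` gives > 300 ug/mL in this assay, again a limit; the limit noted in the limit of > 300 ug/mL in this assay, at which 2 of the 3 values shown sit, holds for two of the three values seen. Compound 4 `CC(C)(C)n1ncc(OCc2nnc(-c3cc(F)c(F)cc3F)o2)c(Cl)c1=O` differs from compound 3 by 2,4,5-trifluorophenyl in place of methyl on an aromatic carbon. This change runs opposite to the step from compound 1 to compound 3, so a downward step in this assay beyond the scatter is expected, roughly undoing that loss. Compound 4 is thus estimated at 25 ug/mL, with a range from 8 ug/mL to 150 ug/mL, a step of an at least 12-fold lower number from compound 3 to compound 4 (1.07 log units; beyond the scatter) expected.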

Compound 4, half-maximal effective concentration: 75.7 ug/mL
For compound 4 the middle estimate is 3.0-fold (0.48 log units) below the measured one; the range from low to high includes it.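

In this assay a second ring on this aromatic carbon also gives a measured value in place of methyl (an at least 3.9-fold lower number from compound 3 to compound 4 (0.59 log units; beyond the scatter)), so the gain seen with 4-methylphenyl is not confined to that one group. The two rings do not give the same result, however (a 3.8-fold higher number from compound 1 to compound 4 (0.58 log units; beyond the scatter)), which shows that what the ring carries counts as well as the ring itself. Compound 3 remains a limit of the assay and not a number, so the first of these steps is only a bound: the limit of > 300 ug/mL in this assay, at which 2 of the 4 values shown sit.

The compounds shown leave open whether a ring is needed here at all, or whether a longer chain or an amine on this carbon would serve as well. They also do not show which of the three fluorine atoms matters, or how an unsubstituted phenyl or a 4-chlorophenyl would compare on this core.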